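This account rests on a few compounds, and the source may have more. Where it says the series, first, only, none or still open, it means among the compounds named here.

Compound 2 `Cn1c(-c2ccccc2F)nnc1[S+](C)[O-]` was tested in a functional assay on the whole organism for antagonist activity, with Mus musculus as the target; a lower number here means that less compound is needed, a higher number that more compound is needed for the effect. In this assay, within the data shown here, compound 2 gives 57.9 mg/kg, which is the only plain number among the two values recorded so far. Compound 1 `Cn1c(-c2ccccc2)nnc1[S+](C)[O-]` differs from compound 2 only by carrying hydrogen where compound 2 carries fluoro. In this assay compound 1 reaches only the limit of the assay, > 100 mg/kg, so no number is known for it; this is described as the limit of > 100 mg/kg in this assay, at which 1 of the 2 values shown sits. The step between these two compounds, an at least 1.7-fold lower number from compound 1 to compound 2 (0.23 log units; that floor lies within the scatter), concerns a fluoro in place of hydrogen on an aromatic carbon.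

Compound 3 `CC[S+]([O-])c1nnc(-c2ccccc2F)n1C` has not yet been measured. It differs from compound 2 in one place:
methyl in place of hydrogen on a saturated chain carbon bound to a sulfur
Among the measured compounds shown here, this change sits on a saturated chain carbon bound to a sulfur, a different place from the single measured step, so that step offers no direct guide, and no step beyond the usual scatter is expected in this assay. Compound 3 is therefore estimated to give about 58 mg/kg in this assay, with a range from 25 mg/kg to 130 mg/kg, which means an expected step of a 1.0-fold higher number from compound 2 to compound 3 (0.00 log units; within the scatter).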

Compound 3, dose for half-maximal effect: > 200 mg/kg
Compound 3: a limit, no number; the forecaster's own chance of this, stated with the estimate: 20%; at least 3.4-fold (0.53 log units) between middle value and limit.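

In this assay, methyl in place of hydrogen on a saturated chain carbon bound to a sulfur, which turns methyl into ethyl, gives an at least 3.4-fold higher number from compound 2 to compound 3 (0.53 log units; beyond the scatter). Among these compounds, this is the first sign that this place in the molecule responds to change, and even an addition as small as a methyl moves the result towards more compound being needed, a direction the fluoro step on the aromatic carbon did not show. The size of this step is only a floor, since the value of compound 3 is a limit and not a number: the limit of > 200 mg/kg in this assay, at which 1 of the 3 values shown sits.

As far as these compounds go, how much more compound would be needed for the effect therefore stays unknown, so the true step could be larger than the one printed. The compounds shown leave open whether a longer chain such as propyl, or an amine, on this same carbon would push the number further in this direction, and whether the hydrogen-to-fluoro change on the aromatic carbon would have any effect with ethyl in place of methyl.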